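The source may hold more compounds than are shown below. What is called first, only, known or untested is meant among the compounds shown, and "the series" means these compounds.

Of the compounds shown here, three in this set have been tested in a toxicity assay on Vero cells (Chlorocebus sabaeus) for inhibition, read by MTT assay, with a stated time of 48 h (on this read-out lower numbers stand for stronger inhibition and higher numbers for weaker inhibition), and only one of them gives a number. Compound 1 `O=C(N/N=C/c1c(-c2cc3ccccc3oc2=O)[nH]c2ccccc12)c1ccccc1Cl` sits at a limit of the assay rather than at a measured value, reported in this assay as > 200000 nM. Compound 2 `O=C(N/N=C/c1c(-c2cc3ccccc3oc2=O)[nH]c2ccccc12)c1cccc(Br)c1` also stands at a limit, reported in this assay as > 200000 nM. Going by the values given here, compound 3 `O=C(N/N=C/c1c(-c2cc3ccc(Br)cc3oc2=O)[nH]c2ccccc12)c1ccccc1Cl` is therefore the only one with a read number, giving 89300 nM in this assay. Among the compounds with values here, the step of an at least 2.2-fold lower number from compound 1 to compound 3 (0.35 log units; beyond the scatter) is the one readable step, while the step that the two limits leave unreadable from compound 1 to compound 2 cannot be sized, which follows from the limit of > 200000 nM in this assay, at which 2 of the 3 values shown sit.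

Compound 4 `O=C(N/N=C/c1c(-c2cc3ccc(Br)cc3oc2=O)[nH]c2ccccc12)c1cccc(Br)c1` differs from compound 3 in one place: 3-bromophenyl in place of 2-chlorophenyl on a carbonyl carbon. Within the data shown here, the only measured step of the same kind, from compound 1 to compound 2, runs between two limits and gives no size. There is thus no readable guide to how large a change to expect, and the estimate for compound 4 rests on compound 3 alone, with a wide range and a real chance of a limit. The expected step of a 1.3-fold higher number from compound 3 to compound 4 (0.13 log units; within the scatter) is accordingly small, and compound 4 is estimated at 120000 nM in this assay, between 40000 nM and 300000 nM.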

Compound 4, half-maximal inhibitory concentration: > 200000 nM
Compound 4: only a limit was reported (the forecaster's own chance of this, stated with the estimate: 40%); middle value at least 1.6-fold (0.22 log units) away from the limit.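

Compound 4 gives the first readable size for this change at this position, the carbonyl carbon whose other neighbour is the amide-type nitrogen: 3-bromophenyl in place of 2-chlorophenyl gives an at least 2.2-fold higher number from compound 3 to compound 4 (0.35 log units; beyond the scatter), which means weaker inhibition in this assay. The value of compound 4, > 200000 nM, is a limit and not a number. Adding the bromo to the shared core gave a readable step when 2-chlorophenyl was present, but the same addition with 3-bromophenyl, from compound 2 to compound 4, cannot be read, and neither can the swap from compound 1 to compound 2, because both members of each pair sit at the same limit: the limit of > 200000 nM in this assay, at which 3 of the 4 values shown sit.

The change from 2-chlorophenyl to 3-bromophenyl alters both the halogen and its place on the ring, so the compounds shown cannot say which of the two matters; 3-chlorophenyl or 2-bromophenyl on the same carbonyl carbon would separate them. Going by these compounds, it also remains open how this position would respond to a group without a halogen, such as an aminophenyl or a carboxylic acid on the phenyl ring.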